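This account rests on a few compounds, and the source may have more. Where it says the series, first, only, none or still open, it means among the compounds named here.

Working notes on the series.

Three compounds have numbers in a functional assay on KB cells (Homo sapiens) for cytotoxicity, read by sulforhodamine B assay; on this read-out higher numbers stand for weaker inhibition and lower numbers for stronger inhibition. Compound 1, `C=C1[C@@H](C/C=C2/C(=O)OC[C@H]2OC(C)=O)[C@]2(C)CC[C@@H](OC(C)=O)[C@@](C)(CO[Si](C)(C)C(C)(C)C)[C@H]2C[C@@H]1O`, gives 9790 nM. Compound 2, `C=C1[C@@H](OC(C)=O)C[C@@H]2[C@](C)(COC=O)[C@H](OC(C)=O)CC[C@@]2(C)[C@@H]1C[C@@H](Nc1ccc(Br)cc1)C1=CCOC1=O`, gives 24000 nM. Compound 3, `C=C1[C@@H](OC(C)=O)C[C@@H]2[C@](C)(CO[Si](C)(C)C(C)(C)C)[C@H](OC(C)=O)CC[C@@]2(C)[C@@H]1C[C@@H](Nc1ccc(OC)cc1)C1=CCOC1=O`, gives 5630 nM. Compound 2 thus stands at the highest number of the three; compound 1 is the nearer of the other two and compound 3 the further, and both gaps lie beyond the usual scatter, so compound 2 is the weakest of the three in this assay.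

Compound 4, `C=C1[C@@H](OC(C)=O)C[C@@H]2[C@](C)(COC=O)[C@H](OC(C)=O)CC[C@@]2(C)[C@@H]1C[C@@H](Nc1ccccc1C(=O)O)C1=CCOC1=O`, has not been measured. It differs from compound 2 in one place: 2-carboxyphenyl in place of 4-bromophenyl on an amine nitrogen. Going by the values given here, no step between measured compounds shows this change on its own, and compound 3 differs from compound 2 in two places at once, so its lower number cannot be tied to the aryl group alone.

Among the compounds with values here, with no direct precedent, the step from compound 2 to compound 4 is expected to be small, a 1.2-fold lower number from compound 2 to compound 4 (0.08 log units; within the scatter), with no firm direction beyond the scatter. Compound 4 is therefore estimated at 20000 nM in this assay, within a range from 6000 nM to 60000 nM.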

Compound 4, half-maximal inhibitory concentration: 42500 nM
Compound 4: middle estimate off by 2.1-fold (0.33 log units), on the low side; the range from low to high includes it.
By their numbers in this assay, from the lowest: compounds 3 and 1 (each within the scatter of the next); then compounds 2 and 4 (each within the scatter of the next).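

In this assay, going by these compounds alone, the exchange of 4-bromophenyl for 2-carboxyphenyl on the amine nitrogen is the first change that can be read in one place alone, and it gives a 1.8-fold higher number from compound 2 to compound 4 (0.25 log units; within the scatter). The amine nitrogen thus carries two quite different aryl groups, one holding a bromine and the other a carboxylic acid with its added hydrogen-bond donor and acceptor, and the two numbers cannot be told apart in this read-out, so this single step gives no sign that the choice between these two groups matters here. Nothing on hand bears on why the step has this size.

One step with two aryl groups does not describe the position as a whole: an unsubstituted phenyl, the methyl ester of the carboxylic acid or a plain alkyl chain on the same nitrogen could still read differently. As far as these compounds go, it also remains open whether any group at this position moves the number beyond the scatter, and whether the same exchange reads alike on the core of compound 3.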